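Bromo for Fluoro on the Phenyl Ring: Expected Outcome

The source may report more compounds than this note shows. Statements on the series, on what has been measured and on what is new or still open speak of the compounds shown alone.

Measured compounds so far:
compound 1 `C/C(=N\Nc1nc(-c2ccc(Br)cc2)cs1)c1sc(C)nc1C` — > 100 ug/mL
compound 2 `C/C(=N\Nc1nc(-c2ccc(F)cc2)cs1)c1sc(-c2ccccc2)nc1C` — > 100 ug/mL

In a toxicity assay on MCF7 cells (Homo sapiens) for cytotoxicity, read by MTT assay (a lower number here means a stronger inhibitor of growth, a higher number a weaker inhibitor of growth), compound 1 gives > 100 ug/mL, which is a limit of the assay rather than a number. Compound 2 gives > 100 ug/mL in this assay, again a limit and not a measured number. For the measured compounds named here, compound 2 therefore stands at the edge of what this assay can report, and the only other value shown sits at that same edge (the limit of > 100 ug/mL in this assay, at which 2 of the 2 values shown sit). Going by the values given here, no two measured compounds differ in just one place, so no measured step is available.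

Compound 3 `C/C(=N\Nc1nc(-c2ccc(Br)cc2)cs1)c1sc(-c2ccccc2)nc1C` differs from compound 2 by bromo in place of fluoro on an aromatic carbon. With both shown values at the limit, there is no measured step on which to build a direction for this change, and the expected step from compound 2 to compound 3 is none beyond the scatter a step that the limit leaves unreadable from compound 2 to compound 3. Compound 3 is accordingly expected to give about 150 ug/mL, within 60 ug/mL to 400 ug/mL, most probably reported only as a limit.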

Compound 3, concentration for 50% growth inhibition: 26.3 ug/mL
Beside the measured number, compound 3's estimate is 5.7-fold (0.76 log units) above it; the whole stated range lies above it.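

In this assay, compound 3 is the only compound shown that gives a measured number rather than a limit, so changes around it can now be read for the first time. On this aromatic carbon, para to a large group, bromo in place of fluoro gives an at least 3.8-fold lower number from compound 2 to compound 3 (0.58 log units; beyond the scatter), and on the other side of the molecule phenyl in place of methyl gives an at least 3.8-fold lower number from compound 1 to compound 3 (0.58 log units; beyond the scatter), so among the compounds shown a measurable growth inhibition appears only where the 4-bromophenyl and the phenyl occur together, and removing either one returns the compound to the limit. Each step is a minimum whose true size stays unknown, because one end of each rests on a limit: the limit of > 100 ug/mL in this assay, at which 2 of the 3 values shown sit.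

The compounds shown leave open whether chloro or iodo at the same place would keep this inhibition, or whether it is specific to bromo among such groups, and what a methoxy or a nitrile there would do. Going by these compounds, it also remains open whether a group other than phenyl in the place of the methyl, such as a longer chain or an amine, would serve as well.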